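The compounds below may be only part of what the source reports. "The series", "measured", "known", "first", "only" and "open" are said of these compounds alone.

Measured compounds:
- compound 1 `COc1cc(-c2nn(-c3cccc(NC(=O)Nc4ccc(Cl)c(Cl)c4)c3)cc2-c2ccncc2)ccc1Cl`: 27600 nM
- compound 2 `O=C(Nc1cccc(-n2cc(-c3ccncc3)c(-c3ccc(Cl)c(O)c3)n2)c1)Nc1ccc(Cl)c(Cl)c1`: 16100 nM
- compound 3 `O=C(Nc1cccc(-n2cc(-c3ccncc3)c(-c3ccc(Cl)c(O)c3)n2)c1)Nc1cc(C(F)(F)F)cc(C(F)(F)F)c1`: 2120 nM

In a functional assay on BT-549 cells (Homo sapiens) for inhibition, read by sulforhodamine B assay, with a stated time of 48 h (a lower number here means a stronger inhibitor of growth, a higher number a weaker inhibitor of growth), compound 1 stands at the high end of the three numbers. Its closest neighbour is compound 2, reached by a 1.7-fold lower number from compound 1 to compound 2 (0.23 log units; within the scatter), a step that stays within the scatter. The furthest is compound 3; compound 2 and compound 3 share the same core and differ only in the urea aryl, where compound 3 carries two trifluoromethyl groups and gives the lowest number of the three.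

Compound 4 `COc1cc(-c2nn(-c3cccc(NC(=O)Nc4ccc(Cl)c(C(F)(F)F)c4)c3)cc2-c2ccncc2)ccc1Cl` is obtained from compound 1 by trifluoromethyl in place of chloro on an aromatic carbon. Within the data shown here, no measured step shows exactly this swap. The one listed step, from compound 1 to compound 2, concerns a different part of the molecule and is within the scatter, so it says nothing about the urea aryl. Among the measured compounds shown here, the only pointer is the pair compound 2 and compound 3, whose values differ beyond the scatter when chloro groups give way to trifluoromethyl groups on that ring. On this basis compound 4 is expected to show a modestly lower number than compound 1, a step of roughly a 2.5-fold lower number from compound 1 to compound 4 (0.40 log units; beyond the scatter), though it could also stay within the scatter. Compound 4 is therefore estimated at 11000 nM in this assay, within a range of 4000 nM to 30000 nM.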

Compound 4, concentration for total growth inhibition: 10200 nM
Compound 4: the middle estimate sits 1.1-fold (0.03 log units) above what was measured, and the stated range covers the measured number.
By their numbers in this assay, from the lowest: compound 3; then compounds 4, 2 and 1 (each within the scatter of the next, the first and the last beyond it).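

In this assay, among these compounds, the change from 3,4-dichlorophenyl to 4-chloro-3-(trifluoromethyl)phenyl gives a 2.7-fold lower number from compound 1 to compound 4 (0.43 log units; beyond the scatter), the first reading of a single swap on this ring with everything else in the molecule held constant. The step is modest, but it lies beyond the scatter, whereas the earlier single change at the oxygen on the other aromatic ring, a 1.7-fold lower number from compound 1 to compound 2 (0.23 log units; within the scatter), did not; this position on the urea aryl therefore responds measurably to trifluoromethyl in place of chloro, ortho to a chloro group and meta to a large group. Nothing available bears on why this replacement lowers the number, so the result stands as an observation without an explanation.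

The compounds shown leave open whether a smaller or different group at this position, such as a methyl group, a bromine atom or a nitrile, would lower the number as trifluoromethyl does. They also leave open whether the same swap would give a step of similar size on the core of compound 2, which carries a hydroxy group in place of the methoxy group.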